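The compounds below may be only part of what the source reports. "The series", "measured", "known", "first", "only" and "open" are said of these compounds alone.

Measured so far in an ADME assay on microsomes from liver (Rattus norvegicus) for metabolic stability; on this read-out lower numbers stand for a shorter-lived compound and higher numbers for a longer-lived compound:

Compound 1, `CC(C)(/C=C1\OC(=O)NC1=O)c1ccc(-c2ccc3cccc(F)c3c2)[nH]c1=O`: > 3 h — a limit of the assay, not a number.
Compound 2, `O=C1NC(=O)/C(=C/C(c2ccc(-c3ccc4cccc(F)c4c3)[nH]c2=O)C2CC2)O1`: > 3 h — also a limit of the assay, not a number.
Compound 3, `CC(C)C(c1ccc(-c2ccc3cccc(F)c3c2)[nH]c1=O)C1C(=O)NC(=O)N1C`: 0.263 h

Compound 2 stands at the limit of > 3 h in this assay, at which 2 of the 3 values shown sit; only a limit is known for it, so its true half-life is not pinned to a number. For the measured compounds named here, compound 3 sits far lower, but it differs from compound 2 in several places at once, so no single step is read from that pair.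

Compound 4, `O=C1NC(=O)/C(=C/C(c2ccc(-c3ccc4cccc(F)c4c3)[nH]c2=O)C2CCCC2)O1`, has not been measured. Its change against compound 2 is cyclopentyl in place of cyclopropyl on a saturated chain carbon bound to an aromatic carbon and a double-bonded chain carbon. Going by the values given here, no measured step of this kind is available; both ring-bearing analogues of this type sit at the limit, and nothing here separates a three-membered ring from a five-membered one. The expected step from compound 2 to compound 4 in this assay is an at least 1.2-fold lower number from compound 2 to compound 4 (0.07 log units; that floor lies within the scatter), that is, none clearly beyond the usual scatter, with some room for a shorter half-life. Compound 4 is therefore estimated at 2.5 h in this assay, within 1 h to 3.5 h.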

Compound 4, half-life: > 3 h
Compound 4 was reported as a limit; the forecaster's own chance of this, stated with the estimate: 45%; middle value at least 1.2-fold (0.07 log units) away from the limit.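

In this assay compound 4 gives > 3 h as a limit of the assay and not a number. For the compounds shown here, compound 2 also sits at a limit, so no step between compound 2 and compound 4 can be read: the limit of > 3 h in this assay, at which 3 of the 4 values shown sit.

The compounds shown leave open whether cyclopentyl and cyclopropyl at this place differ in half-life at all.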